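The source may hold more compounds than are shown below. What is called first, only, known or untested is meant among the compounds shown, and "the series" means these compounds.

Compound 1 `CCN(C)C(=O)N1CCN(C(=S)SCc2cn(Cc3ccccc3F)nn2)CC1`, in a functional assay on MGC-803 cells (Homo sapiens) for cytotoxicity, read by MTT assay, with a stated time of 72 h; on this read-out higher numbers stand for weaker inhibition and lower numbers for stronger inhibition: 5860 nM
Compound 2 `CC(C)(C)NC(=O)N1CCN(C(=S)SCc2cn(Cc3ccccc3F)nn2)CC1`, in this assay: 40700 nM
Compound 3 `O=C(NCc1ccccc1)N1CCN(C(=S)SCc2cn(Cc3ccccc3F)nn2)CC1`, in this assay: 13300 nM

Among these three, compound 1 has the lowest number in this assay. Its nearest neighbour is compound 3, reached by a 2.3-fold higher number from compound 1 to compound 3 (0.36 log units; beyond the scatter), and its furthest is compound 2, reached by a 6.9-fold higher number from compound 1 to compound 2 (0.84 log units; beyond the scatter). Between the other two, the step is a 3.1-fold lower number from compound 2 to compound 3 (0.49 log units; beyond the scatter). All three measured steps alter the group on the carbonyl carbon of the shared core and leave the rest of the molecule untouched.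

Compound 4 `CCN(C)C(=O)N1CCN(C(=S)SCc2cn(Cc3ccc(C)cc3)nn2)CC1` differs from compound 1 elsewhere: 4-methylphenyl in place of 2-fluorophenyl on a saturated chain carbon bound to an aromatic nitrogen. Among the measured compounds shown here, none of the measured steps changes that part of the core, so no measured step bears directly on this change; the data give no direction for it. With nothing in the measured steps speaking for a rise or a fall, the expectation for compound 4 in this assay is a step of a 1.0-fold higher number from compound 1 to compound 4 (0.01 log units; within the scatter), that is, none beyond the usual scatter. The estimate for compound 4 in this assay is therefore 6000 nM, with a range from 2500 nM to 16000 nM, a range kept wide to reflect the lack of any measured step on this position.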

Compound 4, half-maximal inhibitory concentration: 8270 nM
Compound 4: the middle estimate sits 1.4-fold (0.14 log units) below what was measured, within the range that was stated.
By their numbers in this assay, from the lowest: compounds 1, 4 and 3 (each within the scatter of the next, the first and the last beyond it); then compound 2.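

Among the compounds shown here, the first step at this position, 4-methylphenyl in place of 2-fluorophenyl on a saturated chain carbon bound to an aromatic nitrogen, stays within the scatter in this assay (a 1.4-fold higher number from compound 1 to compound 4 (0.15 log units; within the scatter)), whereas all three earlier steps, at the group on the carbonyl carbon, lie beyond it. For this one pair, then, the exchange of one substituted phenyl group for the other leaves no readable difference, although it swaps the substituent and its place on the ring at once, so the two changes cannot be told apart and might even offset each other. The data offer no explanation of this outcome.

The compounds shown leave open whether a separate move of either substituent, as in 4-fluorophenyl or 2-methylphenyl, or a different group here, such as a pyridyl ring, a cyclohexyl ring or a chain ending in an amine, would give a step beyond the scatter. They also leave open whether the same exchange would read alike with tert-butylamino or benzylamino on the carbonyl carbon.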